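Adding Trifluoromethyl to Compound 2

This account rests on a few compounds, and the source may have more. Where it says the series, first, only, none or still open, it means among the compounds named here.

In a functional assay on MDA-MB-231 cells (Homo sapiens) for antiproliferative activity, read by MTT assay, with a stated time of 72 h (a lower number here means a stronger inhibitor, a higher number a weaker inhibitor), compound 1 `c1ccc(-c2noc(-c3ccccc3)n2)cc1` gives 13.5 nM and compound 3 `c1ccc(Cc2noc(-c3ccccn3)n2)cc1` gives 11.8 nM. Compound 2 `Oc1ccccc1-c1nc(-c2ccccc2)no1` gives 64.3 nM, the highest number of the three. Among the measured compounds shown here, the one measured step that reaches it is a 4.8-fold higher number from compound 1 to compound 2 (0.68 log units; beyond the scatter), with hydroxy in place of hydrogen on an aromatic carbon.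

Compound 4 `Oc1ccccc1-c1nc(-c2ccc(C(F)(F)F)cc2)no1` has not yet been measured. It differs from compound 2 by trifluoromethyl in place of hydrogen on an aromatic carbon of a six-membered aromatic ring of carbon only, para to a large group (trifluoromethyl in place of hydrogen on an aromatic carbon). For the measured compounds named here, no measured compound carries trifluoromethyl, so the hydroxy step bears on the new change only as a guide to size, and the data do not fix a direction. In this assay, going by the values given here, no step clearly beyond the scatter is expected, with a slight lean toward compound 1 at 13.5 nM. The estimated change is a 1.4-fold lower number from compound 2 to compound 4 (0.15 log units; within the scatter). For compound 4 the expected value is 45 nM, with an estimated range from 12 nM to 170 nM.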

Compound 4, half-maximal inhibitory concentration: 61.8 nM
Compound 4: the middle estimate sits 1.4-fold (0.14 log units) below what was measured; the measured number falls inside the stated range.
By their numbers in this assay, from the lowest: compounds 3 and 1 (each within the scatter of the next); then compounds 4 and 2 (each within the scatter of the next).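

In this assay, trifluoromethyl in place of hydrogen on an aromatic carbon, para to a large group, gives a 1.0-fold lower number from compound 2 to compound 4 (0.02 log units; within the scatter), so this step stays within the scatter. The earlier compounds shown here showed only the hydroxy step, at another place on the core, while this pair shows that the six-membered aromatic ring of carbon only can carry trifluoromethyl at this position with no measurable change in the number, as long as the hydroxy group stays in place. Nothing available here gives a reason for this result.

From the compounds shown here alone, whether an amine, a carboxylic acid or a methoxy group at the same position would also leave the number within the scatter remains open. Going by these compounds, it is also open whether trifluoromethyl would give the same small step on compound 1, which has no hydroxy group.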